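Pyridin-4-yl to (2-oxopyrrolidin-1-yl)methyl: estimate for compound 3

The compounds below may be only part of what the source reports. "The series", "measured", "known", "first", "only" and "open" are said of these compounds alone.

Among the measured compounds shown here, compound 2 `Cn1cnc2c(C#N)nc(-c3ccc(OCc4ccncc4)c(C(F)(F)F)c3)cc21` gives 10 nM in an assay on isolated protein for inhibition of cathepsin S (Homo sapiens), read by fluorescence (on this read-out higher numbers stand for weaker inhibition and lower numbers for stronger inhibition), the lowest of the two numbers so far; the nearest is compound 1 `Cn1cnc2c(C#N)nc(-c3ccc(OCc4cccnc4)c(C(F)(F)F)c3)cc21` with 12.6 nM, and a 1.3-fold lower number from compound 1 to compound 2 (0.10 log units; within the scatter) lies within the scatter. Compound 3 `Cn1cnc2c(C#N)nc(-c3ccc(OCCN4CCCC4=O)c(C(F)(F)F)c3)cc21` differs from compound 2 by (2-oxopyrrolidin-1-yl)methyl in place of pyridin-4-yl on a saturated chain carbon bound to an oxygen on an aromatic ring. For the measured compounds named here, the only measured step swaps one pyridinyl for another and says nothing about moving to a five-membered non-aromatic ring, so no direction is supported by the data and the estimate rests on the parent alone. Compound 3 is expected at 25 nM, within 8 nM to 80 nM. The expected step is a 2.5-fold higher number from compound 2 to compound 3 (0.40 log units; beyond the scatter), with a wide range for lack of a bearing step.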

Compound 3, half-maximal inhibitory concentration: 7.8 nM
Beside the measured number, compound 3's estimate is 3.2-fold (0.51 log units) above it; measured number outside the range, below it.
By their numbers in this assay, from the lowest: compounds 3, 2 and 1 (each within the scatter of the next).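

In this assay, (2-oxopyrrolidin-1-yl)methyl in place of pyridin-4-yl gives a 1.3-fold lower number from compound 2 to compound 3 (0.11 log units; within the scatter), and in place of pyridin-3-yl it gives a 1.6-fold lower number from compound 1 to compound 3 (0.21 log units; within the scatter). This place, on a saturated chain carbon bound to an oxygen on an aromatic ring, therefore does not need a six-membered aromatic ring to keep the number within the scatter, which the two pyridinyl compounds alone could not show. No evidence on the reason for this is at hand. Still open, as far as these compounds go, is how a carboxylic acid, a morpholine amine or a longer chain at this place would read.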